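Swapping a nitrile-bearing chain for an oxime-bearing one

This account rests on a few compounds, and the source may have more. Where it says the series, first, only, none or still open, it means among the compounds named here.

Compound 1 `COc1c(N2CCN(CCC#N)C(C)C2)c(F)cc2c(=O)c(C(=O)O)cn(C3CC3)c12` is tested in an ADME assay on Vero cells (Chlorocebus sabaeus) for cytotoxicity, read by MTT assay, with a stated time of 72 h (on this read-out higher numbers stand for lower toxicity in this test and lower numbers for higher toxicity in this test), where compound 1 gives 500 ug/mL. Compound 2 `COC(=O)CN1CCN(c2c(F)cc3c(=O)c(C(=O)O)cn(C4CC4)c3c2OC)CC1C` gives 500 ug/mL in this assay, and compound 3 `COc1c(N2CCN(CC(C)=O)C(C)C2)c(F)cc2c(=O)c(C(=O)O)cn(C3CC3)c12` gives 500 ug/mL; compound 1 stands level with both. Compound 4 `COc1c(N2CCN(C/C(C)=N/O)C(C)C2)c(F)cc2c(=O)c(C(=O)O)cn(C3CC3)c12` differs from compound 1 by a group of 4 heavy atoms (2 carbon, 1 nitrogen, 1 oxygen; no ring) in place of a group of 3 heavy atoms (2 carbon, 1 nitrogen; no ring), on a saturated chain carbon bound to an amine nitrogen in a ring. Among the compounds with values here, the steps that bear on this are the two that also replace the cyanomethyl group: no change at the digits printed from compound 1 to compound 2 (within the scatter) and no change at the digits printed from compound 1 to compound 3 (within the scatter), while no change at the digits printed from compound 2 to compound 3 (within the scatter) adds nothing beyond the scatter. Within the data shown here, each change at this position so far leaves the read-out where it was, so no step beyond the scatter is expected in this assay for compound 4. Compound 4 is therefore estimated at 500 ug/mL, within 250 ug/mL to 1000 ug/mL, an expected no change at the digits printed from compound 1 to compound 4 (within the scatter).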

Compound 4, half-maximal cytotoxic concentration: 177 ug/mL
For compound 4 the middle estimate is 2.8-fold (0.45 log units) above the measured one, outside the stated range (below it).
By their numbers in this assay, from the lowest: compound 4; then compounds 1, 2 and 3 (each within the scatter of the next).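

In this assay, within the data shown here, this position proves not to be indifferent to every group: the oxime-bearing chain gives a 2.8-fold lower number from compound 1 to compound 4 (0.45 log units; beyond the scatter) and a 2.8-fold lower number from compound 3 to compound 4 (0.45 log units; beyond the scatter) and also a 2.8-fold lower number from compound 2 to compound 4 (0.45 log units; beyond the scatter) and so is the first change here to go beyond the scatter, toward higher toxicity in this test. Heavy-atom count does not track this, as the groups in compound 2 and compound 4 each hold 4 heavy atoms. Nothing measured here explains the lower number. Going by these compounds, whether the oxime hydroxyl matters remains open, as the methyl ether of the oxime would test. So does the outcome with a primary amine on this chain.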